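The source may report more compounds than this note shows. Statements on the series, on what has been measured and on what is new or still open speak of the compounds shown alone.

Measured so far in a functional assay on MCF7 cells (Homo sapiens) for cytotoxicity, read by MTT assay, with a stated time of 96 h; on this read-out lower numbers stand for stronger inhibition and higher numbers for weaker inhibition:
- compound 1 `COc1cc(C(=O)c2cn(-c3ccccc3[N+](=O)[O-])cc2-c2ccccc2)cc(OC)c1OC`: 5000 nM
- compound 2 `COc1cc(C(=O)c2cn(-c3cccc(Cl)c3)cc2-c2ccccc2)cc(OC)c1OC`: 150 nM
- compound 3 `COc1cccc(-n2cc(C(=O)c3cc(OC)c(OC)c(OC)c3)c(-c3ccccc3)c2)c1`: 500 nM

Compound 3, at 500 nM, is the middle of the three, with compound 2 lower and compound 1 higher. Next is compound 4 `COc1cc(C(=O)c2cn(-c3ccc(Cl)cc3)cc2-c2ccccc2)cc(OC)c1OC`, not yet measured in this assay. The change is 4-chlorophenyl in place of 3-methoxyphenyl on an aromatic nitrogen.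

The closest evidence is the methoxy in place of chloro step, a 3.3-fold higher number from compound 2 to compound 3 (0.52 log units; beyond the scatter), which is modest. It shows a chloro-bearing compound with the lower number, but that is a single pair. The steps of a 33-fold lower number from compound 1 to compound 2 (1.52 log units; beyond the scatter) and a 10-fold lower number from compound 1 to compound 3 (1.00 log units; beyond the scatter) are large and modest, but both start from 2-nitrophenyl and so bear less directly on this change. For the measured compounds named here, no measured compound carries 4-chlorophenyl, so the effect of the chloro position is untested.

Going by the values given here, a modest step to a lower number is therefore expected, no larger than the one seen between compound 2 and compound 3. The expected change is a 2.3-fold lower number from compound 3 to compound 4 (0.36 log units; beyond the scatter). For compound 4 the estimate is 220 nM, with an expected range of 60 nM to 800 nM.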

Compound 4, half-maximal inhibitory concentration: 140 nM
Compound 4: the middle estimate sits 1.6-fold (0.20 log units) above what was measured, and the stated range covers the measured number.
By their numbers in this assay, from the lowest: compounds 4 and 2 (each within the scatter of the next); then compound 3; then compound 1.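

In this assay, 4-chlorophenyl in place of 3-chlorophenyl on the aromatic nitrogen gives a 1.1-fold lower number from compound 2 to compound 4 (0.03 log units; within the scatter) and so, in this pair, moving the chloro from one of these ring positions to the other leaves the two numbers indistinguishable. The earlier gap between a chloro-bearing and a methoxy-bearing aryl group rested on a single pair and now has a second case in a 3.6-fold lower number from compound 3 to compound 4 (0.55 log units; beyond the scatter) even though this pair changes both the group and its ring position. For the compounds shown here, the 2-nitrophenyl compound also stays far from the new compound, with a 36-fold lower number from compound 1 to compound 4 (1.55 log units; beyond the scatter) as the step, but it remains the only nitro example, so the nitro group and its ring position cannot be separated. Nothing at hand gives a reason for any of these steps.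

Still open, on these data alone, is whether 2-chlorophenyl on the aromatic nitrogen would sit with the other two chlorophenyl compounds or nearer the 2-nitrophenyl compound, and whether 4-methoxyphenyl would match 3-methoxyphenyl. An amine or a carboxylic acid on this aryl ring, or a longer chain in its place, also lies outside what the compounds shown can tell.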